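The source may hold more compounds than are shown below. What is called first, only, known or untested is meant among the compounds shown, and "the series" means these compounds.

Working notes on the series in a functional assay on SH-SY5Y cells (Homo sapiens) for antiproliferative activity, read by MTT assay, with a stated time of 72 h; a higher number here means a weaker inhibitor, a lower number a stronger inhibitor

Of the compounds shown here, three have been measured. Compound 1 `COc1cc2c(Nc3ccc(C#N)cc3)ncnc2cc1OCCCN1CCN(C)CC1` gives 13000 nM in this assay. Compound 2 `CCN1CCN(CCCOc2cc3ncnc(Nc4ccc(C#N)cc4)c3cc2OC)CC1` gives 5440 nM in this assay. Compound 3 `COc1cc2c(Nc3ccccc3C#N)ncnc2cc1OCCCN1CCN(C)CC1` gives 32400 nM in this assay, the highest number of the three, beyond the scatter against both of the others.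

Two single-point changes connect the measured compounds. From compound 1 to compound 2 the change is methyl in place of hydrogen on a saturated chain carbon bound to an amine nitrogen in a ring, and it made a 2.4-fold lower number from compound 1 to compound 2 (0.38 log units; beyond the scatter), a modest gain. From compound 1 to compound 3 the change is 2-cyanophenyl in place of 4-cyanophenyl on a nitrogen on an aromatic ring; this is also how the core of compound 3 and compound 4 differs from the core of compound 1 and compound 2, and it made a 2.5-fold higher number from compound 1 to compound 3 (0.40 log units; beyond the scatter), a modest loss. Compound 2 and compound 3 are not joined by a single change; their values show compound 2 with the lower number.

Compound 4 `CCN1CCN(CCCOc2cc3ncnc(Nc4ccccc4C#N)c3cc2OC)CC1` has not yet been measured. It differs from compound 3 by methyl in place of hydrogen on a saturated chain carbon bound to an amine nitrogen in a ring, the same change, at the same place, that was made from compound 1 to compound 2. For the measured compounds named here, with only one measured instance of this change to rest on, the step from compound 3 to compound 4 is expected to be about a 2.3-fold lower number from compound 3 to compound 4 (0.36 log units; beyond the scatter), in line with a 2.4-fold lower number from compound 1 to compound 2 (0.38 log units; beyond the scatter). Compound 4 is therefore estimated at 14000 nM, with a likely range from 6000 nM to 32000 nM.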

Compound 4, half-maximal inhibitory concentration: 12600 nM
The estimate for compound 4 lay 1.1-fold (0.05 log units) above the measured number; measured number inside the range.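

In this assay, ethyl in place of methyl on the piperazine gives a 2.6-fold lower number from compound 3 to compound 4 (0.41 log units; beyond the scatter), and the step carries over from the core of compound 1 and compound 2 to the core of compound 3 and compound 4: the same change on two cores in this assay, a 2.4-fold lower number (0.38 log units; beyond the scatter) from compound 1 to compound 2 and a 2.6-fold lower number (0.41 log units; beyond the scatter) from compound 3 to compound 4, 1.1-fold (0.03 log units) apart, within the scatter of two such steps. Read the other way around the same four compounds, 2-cyanophenyl in place of 4-cyanophenyl gives a 2.3-fold higher number from compound 2 to compound 4 (0.36 log units; beyond the scatter), and this change also keeps its size when the piperazine group differs: the same change on two cores in this assay, a 2.5-fold higher number (0.40 log units; beyond the scatter) from compound 1 to compound 3 and a 2.3-fold higher number (0.36 log units; beyond the scatter) from compound 2 to compound 4, 1.1-fold (0.03 log units) apart, within the scatter of two such steps. Both comparisons rest on the same four compounds in a single assay, so they show that the two changes combine without visible interaction here, but they are not independent checks and show nothing about how either change would behave on a different core or in another cell line.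

As far as these compounds go, with only methyl and ethyl at this place on the piperazine, it remains open whether a longer chain such as propyl, or a hydroxyethyl group, would continue the trend toward lower numbers or reverse it. From the compounds shown here alone, it is equally open whether the same transfer would hold if an amide or a carboxylic acid took the place of the nitrile on the phenyl ring.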